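Removing a benzyloxy group: solubility outlook for compound 3

The source may hold more compounds than are shown below. What is called first, only, known or untested is meant among the compounds shown, and "the series" means these compounds.

Measured so far:
compound 1, `Cc1c(-c2ccccc2)c(N2CC[C@H](N(C)C)C2)n2nc(C(C)(C)C)cc2c1C#N`, < 2 ug/mL
compound 2, `Cc1c(-c2ccccc2)c(N2CC[C@H](N(C)C)C2)n2nc(C(C)(C)COCc3ccccc3)nc2c1C#N`, < 3 ug/mL

In a physicochemical assay for solubility, at pH 6.8 (a higher number here means a more soluble compound, a lower number a less soluble compound), compound 1 gives < 2 ug/mL, which is a limit of the assay rather than a number (the limit of < 2 ug/mL in this assay, at which 1 of the 2 values shown sits). In this assay compound 2 gives < 3 ug/mL, likewise a limit and not a number (the limit of < 3 ug/mL in this assay, at which 1 of the 2 values shown sits). Among the measured compounds shown here, compound 2 therefore stands at the floor of what the assay reports, and no measured step between compounds is available.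

Compound 3, `Cc1c(-c2ccccc2)c(N2CC[C@H](N(C)C)C2)n2nc(C(C)(C)C)nc2c1C#N`, differs from compound 2 as follows: hydrogen in place of benzyloxy on a saturated chain carbon, two bonds along the chain from an aromatic carbon.

With both measured values sitting at a limit, the size of the step cannot be read from the data. The account expects compound 3 to rise modestly in this assay, by a step of about an at least 1.6-fold higher number from compound 2 to compound 3 (0.22 log units; that floor lies within the scatter), which may or may not clear the reporting floor. The estimated solubility for compound 3 is 5 ug/mL, in a range from 1 ug/mL to 20 ug/mL.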

Compound 3, solubility: 16 ug/mL
For compound 3 the middle estimate is 3.2-fold (0.51 log units) below the measured one; low and high end bracket the measured number.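

Among the compounds shown here, compound 3 is the first compound here to give a number rather than a limit in this assay, so this position now has a change that can be read: hydrogen in place of benzyloxy on a saturated chain carbon, two bonds along the chain from an aromatic carbon, gives an at least 5.3-fold higher number from compound 2 to compound 3 (0.72 log units; beyond the scatter) and clears the scatter. On these data alone, the true size of that step stays unknown because compound 2 sits at a limit: the limit of < 3 ug/mL in this assay, at which 1 of the 3 values shown sits. Even so, the change from (benzyloxy)methyl to methyl proves large enough to register in this read-out, which the earlier limits alone could not show.

Still open, as far as these compounds go, is how far the step really extends. From the compounds shown here alone, it is also open where a hydroxyl, a methoxy group or a primary amine on that chain carbon would fall relative to hydrogen and benzyloxy.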